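From Amino to Methoxy in a Small Compound Set

The source may hold more compounds than are shown below. What is called first, only, known or untested is meant among the compounds shown, and "the series" means these compounds.

In a functional assay on SW-620 cells (Homo sapiens) for inhibition, read by MTT assay, with a stated time of 48 h (a higher number here means a weaker inhibitor of growth, a lower number a stronger inhibitor of growth), compound 1 (`Nc1ccc(-c2cc(-c3ccccc3)n[nH]2)cc1`) gives 25400 nM and compound 2 (`COc1ccccc1-c1cc(-c2ccc(N)cc2)[nH]n1`) gives 21100 nM so the two sit level, within the scatter of each other. Compound 3 (`COc1ccc(-c2cc(-c3ccccc3)n[nH]2)cc1`) keeps the core of compound 1 and changes one group: methoxy in place of amino on an aromatic carbon with methoxy in place of amino on an aromatic carbon, para to a large group. Among the compounds with values here, only one measured step comes near this change. Compound 2 has methoxy in place of hydrogen on an aromatic carbon and keeps the amino, giving a 1.2-fold lower number from compound 1 to compound 2 (0.08 log units; within the scatter) as that single step. Within the data shown here, no measured compound lacks the amino group, so this step is only a loose guide. No step beyond the scatter is expected in this assay and the estimated step is a 1.2-fold higher number from compound 1 to compound 3 (0.07 log units; within the scatter) with room on either side. For compound 3 the expected value is 30000 nM with an estimated range from 12000 nM to 75000 nM in this assay.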

Compound 3, concentration for 50% growth inhibition: 27200 nM
Compound 3: middle estimate off by 1.1-fold (0.04 log units), on the high side, within the range that was stated.
By their numbers in this assay, from the lowest: compounds 2, 1 and 3 (each within the scatter of the next).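

This is the first compound shown without the amino group, and in this assay replacing amino with methoxy on this aromatic carbon, para to a large group, gives only a small step (a 1.1-fold higher number from compound 1 to compound 3 (0.03 log units; within the scatter)). On the core of compound 1, then, the amino group is not needed to keep the number at this level, although this rests on a single pair of compounds. Nothing shown here explains why the two groups read alike.

On these data alone, it remains open whether a carboxylic acid or a longer chain such as ethoxy at this place would move the number beyond the scatter. Also open, as far as these compounds go, is how methoxy here would read when combined with the methoxy carried by compound 2.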